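Amide aryl swap: compound 2 to compound 3

The source may hold more compounds than are shown below. What is called first, only, known or untested is meant among the compounds shown, and "the series" means these compounds.

Measured compounds:
- compound 1 `COc1ccc(C(=O)Nc2cc(Nc3nccc(-c4cn(C)c5ccccc45)n3)c(OC)cc2F)nc1`: 16800 nM
- compound 2 `COc1ccc(C(=O)Nc2cc(Nc3nccc(-c4cn(C)c5ccccc45)n3)c(OC)cc2N(C)C)nc1`: 2130 nM

In a functional assay on NCI-H1975 cells (Homo sapiens) for antiproliferative activity, read by MTT assay, with a stated time of 72 h (a higher number here means a weaker inhibitor, a lower number a stronger inhibitor), compound 2 gives 2130 nM, the lower of the two numbers; compound 1 gives 16800 nM, separated by a 7.9-fold lower number from compound 1 to compound 2 (0.90 log units; beyond the scatter). Compound 3 `COc1cc(N(C)C)c(NC(=O)c2ccnc(Cl)n2)cc1Nc1nccc(-c2cn(C)c3ccccc23)n1` differs from compound 2 by 2-chloropyrimidin-4-yl in place of 5-methoxypyridin-2-yl on a carbonyl carbon. For the measured compounds named here, the single measured step, a 7.9-fold lower number from compound 1 to compound 2 (0.90 log units; beyond the scatter), concerns a different position and offers no guide to a change on the carbonyl carbon. For compound 3 no step beyond the scatter is expected, a 1.2-fold higher number from compound 2 to compound 3 (0.07 log units; within the scatter), with wide uncertainty. The estimate for compound 3 in this assay is 2500 nM (range 500 nM to 12000 nM).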

Compound 3, half-maximal inhibitory concentration: 3660 nM
Estimate against measurement, compound 3: 1.5-fold (0.17 log units) below; the measured number falls inside the stated range.
By their numbers in this assay, from the lowest: compounds 2 and 3 (each within the scatter of the next); then compound 1.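

On the carbonyl carbon, 2-chloropyrimidin-4-yl in place of 5-methoxypyridin-2-yl gives a 1.7-fold higher number from compound 2 to compound 3 (0.24 log units; within the scatter) in this assay. This position therefore accepts this exchange of one six-membered aromatic ring for another without a step beyond the scatter, which the earlier pair, changed at a different place, could not show. No available evidence explains this result. From the compounds shown here alone, it remains open whether the chlorine matters, as a 2-aminopyrimidin-4-yl group could show, and whether an unsubstituted phenyl on the carbonyl carbon would give a step beyond the scatter.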